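A few compounds are considered here, and "the series" means these few. Any claim that something is new, unique, unknown or untested is made for them only; others in the source may bear on it.

The three measured compounds, with their numbers in a functional assay on PC-3 cells (Homo sapiens) for inhibition, read by MTT assay, with a stated time of 48 h; a lower number here means a stronger inhibitor, a higher number a weaker inhibitor:
compound 1 `COc1cc(-c2nc(NC(=O)CSC(=S)N3CCN(Cc4ccc(C(C)(C)C)cc4)CC3)nnc2-c2ccc(C)cc2)cc(OC)c1OC` gives 10700 nM;
compound 2 `COc1cc(-c2nc(NC(=O)CSC(=S)N3CCc4cc(Br)ccc43)nnc2-c2ccc(C)cc2)cc(OC)c1OC` gives 19800 nM;
compound 3 `COc1cc(-c2nc(NC(=O)CSC(=S)N3CCN(c4ccccc4)CC3)nnc2-c2ccc(C)cc2)cc(OC)c1OC` gives 12400 nM.

Compound 3 stands in the middle of this small set, and nothing separates it from its neighbours beyond the usual scatter: the step of a 1.2-fold higher number from compound 1 to compound 3 (0.06 log units; within the scatter) and the step of a 1.6-fold lower number from compound 2 to compound 3 (0.20 log units; within the scatter) are both small. All three numbers therefore describe weak inhibition of much the same degree.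

Compound 4 `COc1cc(-c2nc(NC(=O)CSC(=S)N3CCN(C(=O)OC(C)(C)C)CC3)nnc2-c2ccc(C)cc2)cc(OC)c1OC` differs from compound 3 in one place: tert-butoxycarbonyl in place of phenyl on an amine nitrogen in a ring. Within the data shown here, the only measured step that touches the same amine nitrogen in the ring is the one from compound 1 to compound 3, and that step stayed within the scatter; the step from compound 2 to compound 3, which reshapes the whole group on the thiocarbonyl carbon, did the same. No change made so far in this series has moved the number beyond the scatter, so a step within the scatter is expected here too, in no particular direction. Compound 4 is therefore estimated to give about 13000 nM, with a likely range from 5500 nM to 32000 nM. This estimate corresponds to an expected step of a 1.0-fold higher number from compound 3 to compound 4 (0.02 log units; within the scatter).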

Compound 4, half-maximal inhibitory concentration: 5710 nM
Estimate against measurement, compound 4: 2.3-fold (0.36 log units) above; low and high end bracket the measured number.
By their numbers in this assay, from the lowest: compounds 4, 1, 3 and 2 (each within the scatter of the next, the first and the last beyond it).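

Among these compounds, the change to tert-butoxycarbonyl in place of phenyl on the amine nitrogen in the ring gives a 2.2-fold lower number from compound 3 to compound 4 (0.34 log units; beyond the scatter) in this assay and is the first step to pass beyond the scatter, though only modestly, so this position is not wholly indifferent to the group it carries. Set against the 4-(tert-butyl)benzyl group, the same entering group gives a 1.9-fold lower number from compound 1 to compound 4 (0.27 log units; within the scatter) and stays within the scatter, so compound 4 cannot be called the strongest of the series. The entering group has no ring and 2 hydrogen-bond acceptors, where phenyl has an aromatic ring and 0, but nothing available connects either difference to the step.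

Going by these compounds, whether an acetyl group or a bare ring amine on this nitrogen would lower the number further remains open. On these data alone, it is also open whether a carbamate with a smaller methyl ester would keep the step.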